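The source may report more compounds than this note shows. Statements on the series, on what has been measured and on what is new or still open speak of the compounds shown alone.

In a functional assay on COLO 205 cells (Homo sapiens) for cytotoxicity (a lower number here means a stronger inhibitor of growth, a higher number a weaker inhibitor of growth), compound 2 `COc1ccc(/N=C/c2cc(OC)c(OC)c(OC)c2)cc1` gives 28600 nM and compound 1 `CCc1ccc(/N=C/c2cc(OC)c(OC)c(OC)c2)cc1` gives 49100 nM, two numbers within the scatter of each other. Compound 3 `CCOc1ccc(/N=C/c2cc(OC)c(OC)c(OC)c2)cc1` turns the methoxy of compound 2 into ethoxy, with methyl in place of hydrogen on a saturated chain carbon bound to an oxygen on an aromatic ring. Going by the values given here, the only measured step that bears on this, a 1.7-fold lower number from compound 1 to compound 2 (0.23 log units; within the scatter), put methoxy in place of ethyl on an aromatic carbon. No change beyond the scatter is therefore expected in this assay. The expected step is a 1.1-fold higher number from compound 2 to compound 3 (0.05 log units; within the scatter). Compound 3 is estimated at 32000 nM, with a range from 15000 nM to 65000 nM.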

Compound 3, concentration for 50% growth inhibition: 75900 nM
For compound 3 the middle estimate is 2.4-fold (0.38 log units) below the measured one; the measured number lies above the stated range.
By their numbers in this assay, from the lowest: compounds 2, 1 and 3 (each within the scatter of the next, the first and the last beyond it).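

In this assay, one added methyl on a saturated chain carbon bound to an oxygen on an aromatic ring gives a 2.7-fold higher number from compound 2 to compound 3 (0.42 log units; beyond the scatter) and so moves the number beyond the scatter, which the earlier step did not do. The other new step is a 1.5-fold higher number from compound 1 to compound 3 (0.19 log units; within the scatter) and stays within the scatter. Nothing available accounts for the methyl step. On these data alone, whether a longer chain such as propoxy would raise the number further stays open, and so does what a hydroxyl or an amine would do in place of the methoxy.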